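A Methyl Added to the 1-Phenylethyl Group on the Amine

The source may hold more compounds than are shown below. What is called first, only, known or untested is meant among the compounds shown, and "the series" means these compounds.

In a functional assay on SK-BR-3 cells (Homo sapiens) for antiproliferative activity (a lower number here means a stronger inhibitor, a higher number a weaker inhibitor), compound 1 `CCN(C)CCCOc1ccc2cc(NC(=O)c3ccc(O)c(CC=C(C)C)c3)c(=O)oc2c1C` gives 730 nM while compound 2 `CC(C)=CCc1cc(C(=O)Nc2cc3ccc(OCCCN(C)C(C)(C)C)c(C)c3oc2=O)ccc1O` gives 880 nM and compound 3 `CC(C)=CCc1cc(C(=O)Nc2cc3ccc(OCCCN[C@H](C)c4ccccc4)c(C)c3oc2=O)ccc1O` gives 1000 nM as its value, which lies within the scatter of both others. Compound 4 `CC(C)=CCc1cc(C(=O)Nc2cc3ccc(OCCCNC(C)(C)c4ccccc4)c(C)c3oc2=O)ccc1O` remains unmeasured. It differs from compound 3 by 1-methyl-1-phenylethyl in place of 1-phenylethyl on an amine nitrogen with 1-methyl-1-phenylethyl in place of 1-phenylethyl on an amine nitrogen. Three measured swaps of the groups on that nitrogen bear on this change: a 1.2-fold higher number from compound 1 to compound 2 (0.08 log units; within the scatter) and a 1.4-fold higher number from compound 1 to compound 3 (0.14 log units; within the scatter) and a 1.1-fold higher number from compound 2 to compound 3 (0.06 log units; within the scatter) all stayed within the scatter. No step beyond the scatter is therefore expected in this assay here. The estimated step is no change at the digits printed from compound 3 to compound 4 (within the scatter) on this evidence. Compound 4 is expected at 1000 nM with 500 nM to 2100 nM as its estimated range.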

Compound 4, half-maximal inhibitory concentration: 960 nM
Compound 4: middle estimate off by 1.0-fold (0.02 log units), on the high side; the range from low to high includes it.
By their numbers in this assay, from the lowest: compounds 1, 2, 4 and 3 (each within the scatter of the next).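

Moving from 1-phenylethyl to 1-methyl-1-phenylethyl on the amine nitrogen adds one carbon and removes the defined stereocentre, yet this assay shows only a 1.0-fold lower number from compound 3 to compound 4 (0.02 log units; within the scatter) for this change. The new group also sits close to the two non-aromatic amines, with a 1.1-fold higher number from compound 2 to compound 4 (0.04 log units; within the scatter) and a 1.3-fold higher number from compound 1 to compound 4 (0.12 log units; within the scatter) as the steps, so all four amine groups shown lie within the scatter. No measurement here explains this flat result. Still open, from the compounds shown here alone, is whether a piperidine or morpholine ring at this nitrogen, or a longer chain leading to it, keeps the number in this range.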